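This account rests on a few compounds, and the source may have more. Where it says the series, first, only, none or still open, it means among the compounds named here.

Compound 1 `COc1nc(-c2ccccc2F)ccc1[C@@H](c1ccccc1)[C@@](O)(CCN(C)C)c1cccc2ccccc12` is the starting point of this comparison. In a toxicity assay on HeLa cells (Homo sapiens) for cytotoxicity (a higher number here means that more compound is tolerated, a lower number that less compound is tolerated), compound 1 has no reported number, and its entry reads "nd" (no result reported). Compound 2 `COc1nc(-c2ccc(C(F)(F)F)cc2)ccc1[C@@H](c1ccccc1)[C@@](O)(CCN(C)C)c1cccc2ccccc12` is a close relative carrying a trifluoromethyl group. In this assay compound 2 reaches only a limit, > 64 ug/mL. Compound 3 `COc1nc(-c2ccc(OC(F)(F)F)cc2)ccc1[C@@H](c1ccccc1)[C@@](O)(CCN(C)C)c1cccc2ccccc12` carries a trifluoromethoxy group in its place. In this assay compound 3 likewise reaches only a limit, > 64 ug/mL. The step that the two limits leave unreadable from compound 2 to compound 3 therefore cannot be read, as both ends are limits. The picture so far is summed up by the limit of > 64 ug/mL in this assay, at which 2 of the 3 values shown sit.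

Compound 4 `COc1nc(-c2ccccc2Cl)ccc1[C@@H](c1ccccc1)[C@@](O)(CCN(C)C)c1cccc2ccccc12` differs from compound 1 by chloro in place of fluoro on an aromatic carbon. Going by the values given here, no measured step covers this particular change, and compound 1 itself has no number, so nothing in the data points toward a shift in either direction. The expectation rests only on the limits reached by compound 2 and compound 3 in this assay. Compound 4 is therefore expected to give another limit rather than a number, with an estimated value of 64 ug/mL and an expected range from 32 ug/mL to 128 ug/mL.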

Compound 4, half-maximal cytotoxic concentration: > 64 ug/mL
Compound 4 ended at the assay's limit; the forecaster's own chance of this, stated with the estimate: 80%; the middle value sits exactly at the limit.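

The steps from compound 2 and from compound 3 to compound 4 cannot be read, because all three compounds give a limit rather than a number: the limit of > 64 ug/mL in this assay, at which 3 of the 4 values shown sit.

The compounds shown leave open at what concentration any of them becomes toxic in this assay, and whether chloro in place of fluoro changes that from compound 1 to compound 4.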